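A few compounds are considered here, and "the series" means these few. Any claim that something is new, unique, unknown or untested is made for them only; others in the source may bear on it.

Measured so far:
compound 1, `COc1cc2c(cc1OC)C(CC(=O)N(C)C)CC2`: 23.3%
compound 2, `CCN(CC)C(=O)CC1CCc2cc(OC)c(OC)cc21`: 16.7%
compound 3, `COc1cc2c(cc1OC)C(CC(=O)NC1CCCCC1)CC2`: 53.3%

In a functional assay on the whole organism (strain Wistar) for inhibition, with Rattus norvegicus as the target, read by paw edema, with stated times of 60 min and 24 h, at a dose of 100 mg/kg by the oral route (on this read-out lower numbers stand for less inhibition and higher numbers for more inhibition at the one dose given (going by the name of the read-out)), compound 3 holds the highest number of the three: it stands a number 30 percentage points higher from compound 1 to compound 3 (beyond the scatter) and a number 36.6 percentage points higher from compound 2 to compound 3 (beyond the scatter), both beyond the scatter, while compound 1 and compound 2 lie within the scatter of each other, a number 6.6 percentage points lower from compound 1 to compound 2 (within the scatter). Compound 4, `COc1cc2c(cc1OC)C(CC(=O)NCc1ccccc1)CC2`, is the next step from compound 3: benzyl in place of cyclohexyl on an amide-type nitrogen. Going by the values given here, no measured step swaps one group on the amide nitrogen for another while keeping the amide hydrogen; the only steps that bear on it are those from dimethylamino and diethylamino to cyclohexylamino, and compound 4 keeps the amide hydrogen of compound 3. A small step downward, not clearly beyond the scatter, is expected, a number 8.3 percentage points lower from compound 3 to compound 4 (within the scatter). Compound 4 is expected to give 45%, in the range 25% to 65%.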

Compound 4, a percentage reported as inhibition, in the whole organism at one dose (the size of the read-out at that dose, not a potency): 43.3%
For compound 4 the middle estimate is 1.7 percentage points above the measured one; measured number inside the range.
By their numbers in this assay, from the lowest: compounds 2 and 1 (each within the scatter of the next); then compounds 4 and 3 (each within the scatter of the next).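

In this assay, benzyl in place of cyclohexyl on an amide-type nitrogen gives a number 10 percentage points lower from compound 3 to compound 4 (within the scatter), so an aromatic and a non-aromatic six-membered ring cannot be told apart at this position. The rise over the dialkylamino amides no longer rests on cyclohexylamino alone: a number 26.6 percentage points higher from compound 2 to compound 4 (beyond the scatter) and a number 20 percentage points higher from compound 1 to compound 4 (beyond the scatter), and none of the four compounds goes against this. Nothing at hand explains these steps.

Going by these compounds, whether the ring or the amide hydrogen carries the rise stays open, which a methyl on that nitrogen would address. On these data alone, a longer chain such as phenethyl, or an amine or carboxylic acid on the benzyl ring, also remains open.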